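Swapping a Ring Nitrogen for Carbon

A few compounds are considered here, and "the series" means these few. Any claim that something is new, unique, unknown or untested is made for them only; others in the source may bear on it.

Three close relatives of one shared core are followed here. Compound 1 `Cc1n[nH]c2ccc(-c3nc4cnc(N5CCN(C)CC5)cn4c3Nc3ccc(F)cc3)cc12` and compound 2 `Cc1n[nH]c2ccc(-c3nc4cnc(N5CCN(C)CC5)cn4c3Nc3ccc(Cl)cc3)cc12` differ from each other only in one halogen. In a functional assay on CWR22R cells (Homo sapiens) for inhibition, with a stated time of 120 h, tested at 10 uM (on this read-out lower numbers stand for less inhibition and higher numbers for more inhibition at the one concentration tested (going by the name of the read-out)), compound 1 gives "not determined" (no result reported), so it offers nothing to compare. In this assay compound 2 gives 8.11%, a small degree of inhibition at the single concentration tested, and since this is the only number shown, compound 2 stands alone with nothing to rank it against and no step between two measured compounds to lean on.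

Compound 3 `Cc1n[nH]c2ccc(-c3nc4cnc(N5CCC(C)CC5)cn4c3Nc3ccc(Cl)cc3)cc12` changes compound 2 in a single place: 4-methylpiperidin-1-yl in place of 4-methylpiperazin-1-yl on an aromatic carbon. What this exchange does to inhibition cannot be read from any measured pair, so the expectation must rest on the small value of compound 2 itself. The step from compound 2 to compound 3 is therefore expected to be small, in no particular direction, and not beyond the usual scatter: a number 0.1 percentage points lower from compound 2 to compound 3 (within the scatter). Compound 3 is accordingly estimated at 8%, with a range from -6% to 24%.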

Compound 3, a percentage reported as inhibition, at one concentration (the size of the read-out at that concentration, not a potency): 12.6%
The estimate for compound 3 lay 4.6 percentage points below the measured number; the measured number falls inside the stated range.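

Among the compounds shown here, the first step that can be read at this position is a number 4.5 percentage points higher from compound 2 to compound 3 (within the scatter) in this assay, and it comes from a very small edit. On this aromatic carbon, 4-methylpiperidin-1-yl takes the place of 4-methylpiperazin-1-yl, which keeps the six-membered ring and its seven heavy atoms but swaps one ring nitrogen for carbon and leaves one hydrogen-bond acceptor fewer, and this read-out cannot tell compound 2 and compound 3 apart, with both showing only a small degree of inhibition at the one concentration tested. Nothing measured here offers an explanation for this result.

From the compounds shown here alone, whether any other group at this position would move the read-out beyond the usual scatter stays open, for example a morpholine ring, a primary amine on a short carbon chain, or a carboxylic acid. A single pair also cannot show whether the same swap of nitrogen for carbon would read the same way on a core carrying a different halogen, or on a compound with much stronger inhibition to begin with.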